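Methoxy in place of chloro: expectation for compound 4

This account rests on a few compounds, and the source may have more. Where it says the series, first, only, none or still open, it means among the compounds named here.

Measured so far in a physicochemical assay for lipophilicity; a higher number here means a more lipophilic compound, a lower number a more polar compound:
- compound 1 `O=C1/C(=C/c2ccc(Cl)cc2)CCC/C1=C\c1ccccc1[N+](=O)[O-]`: 5.38
- compound 2 `COc1ccc(/C=C2\CCC/C(=C\c3ccccc3[N+](=O)[O-])C2=O)cc1`: 4.76
- compound 3 `O=C1/C(=C/c2ccc(Cl)cc2)CCC/C1=C\c1cccc([N+](=O)[O-])c1`: 5.58

Compound 3 lies within the scatter of compound 1 and beyond the scatter above compound 2. Compound 4 `COc1ccc(/C=C2\CCC/C(=C\c3cccc([N+](=O)[O-])c3)C2=O)cc1` differs from it by methoxy in place of chloro on an aromatic carbon, para to a large group. Among the measured compounds shown here, one measured step bears on this, the same exchange: a number 0.62 log units lower from compound 1 to compound 2 (beyond the scatter), modest and beyond the scatter. For the measured compounds named here, with only that single precedent, a modest fall in this assay of similar size is expected. The expected change is a number 0.62 log units lower from compound 3 to compound 4 (beyond the scatter). For compound 4 the estimated value is 4.96, with an expected range of 4.6 to 5.3.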

Compound 4, partition coefficient: 4.96
Compound 4: the middle estimate sits on the measured number at the digits printed; low and high end bracket the measured number.
By their numbers in this assay, from the lowest: compounds 2 and 4 (each within the scatter of the next); then compounds 1 and 3 (each within the scatter of the next).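

In this assay the exchange of 4-chlorophenyl to 4-methoxyphenyl gives a number 0.62 log units lower from compound 3 to compound 4 (beyond the scatter) and so matches a number 0.62 log units lower from compound 1 to compound 2 (beyond the scatter) in size. The exchange therefore holds with the nitro group placed as in compound 3 as well as placed as in compound 1, though only these two pairs support it. No measurement available here accounts for the size of this step.

From the compounds shown here alone, whether an amine or a carboxylic acid at the same position would give a comparable step remains open. So does whether the exchange keeps its size with a nitrile in place of the nitro group.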